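Swapping the dimethoxyphenyl group: a projection for compound 4

The compounds below may be only part of what the source reports. "The series", "measured", "known", "first", "only" and "open" are said of these compounds alone.

Compound 1 `COc1ccc(OC)c(-c2cc(-c3ccccc3)nn2-c2ccc(S(N)(=O)=O)cc2)c1` gives 13900 nM in a functional assay on cells (Cancer cell lines, Homo sapiens) for cytotoxicity, read by sulforhodamine B assay, with a stated time of 48 h; on this read-out higher numbers stand for weaker inhibition of growth and lower numbers for stronger inhibition of growth. Compound 2 `COc1ccc(OC)c(-c2cc(-c3ccccc3)nn2-c2ccc(S(=O)(=O)NC(C)=O)cc2)c1`, which carries acetyl in place of hydrogen on the sulfonamide nitrogen, gives 12000 nM; the step of a 1.2-fold lower number from compound 1 to compound 2 (0.06 log units; within the scatter). Compound 3 `COc1ccc(OC)c(-c2cc(-c3ccc(Cl)cc3)nn2-c2ccc(S(=O)(=O)NC(C)=O)cc2)c1`, with chloro in place of hydrogen on an aromatic carbon of its phenyl group, gives 3610 nM, and the step of a 3.3-fold lower number from compound 2 to compound 3 (0.52 log units; beyond the scatter). Among the three numbers compound 2 stands second highest: compound 1 is its nearest neighbour and lies within the scatter of it, compound 3 is its furthest and lies beyond the scatter.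

Compound 4 `CC(=O)NS(=O)(=O)c1ccc(-n2nc(-c3ccccc3)cc2C2=CC(=O)C=CC2=O)cc1` differs from compound 2 by a group of 8 heavy atoms (6 carbon, 2 oxygen; one six-membered non-aromatic ring of carbon only) in place of a group of 10 heavy atoms (8 carbon, 2 oxygen; one six-membered aromatic ring of carbon only), on an aromatic carbon: the 2,5-dimethoxyphenyl leaves and a six-membered non-aromatic ring of carbon only with 4 double bonds outside aromatic rings enters, on the aromatic carbon of the five-membered aromatic ring with 2 nitrogen, next to the ring nitrogen. Neither measured step touches this position: the change seen in compound 2 alters the sulfonamide nitrogen, the change seen in compound 3 alters the phenyl group. Among the compounds with values here, no measured step therefore bears on this replacement, and the series gives no direction for this assay. The step of no change at the digits printed from compound 2 to compound 4 (within the scatter) is accordingly expected to stay close to nothing beyond the scatter, with a wide range for an untested exchange. Compound 4 is expected to give 12000 nM, within a range from 3500 nM to 40000 nM.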

Compound 4, concentration for 50% growth inhibition: 100000 nM
Beside the measured number, compound 4's estimate is 8.3-fold (0.92 log units) below it; the measured number lies above the stated range.
By their numbers in this assay, from the lowest: compound 3; then compounds 2 and 1 (each within the scatter of the next); then compound 4.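

In this assay, within the data shown here, this position on the shared core proves far from silent: an 8.3-fold higher number from compound 2 to compound 4 (0.92 log units; beyond the scatter) is the largest step so far. It runs against the step on the phenyl group, where a 3.3-fold lower number from compound 2 to compound 3 (0.52 log units; beyond the scatter) goes toward stronger inhibition of growth, so the series now holds one exchange that strengthens the read-out and one that weakens it, at two different places. The 2,5-dimethoxyphenyl therefore cannot be exchanged for the six-membered non-aromatic ring of carbon only without a clear loss on this read-out, though no measurement on hand bears on why the number rises.

Open, going by these compounds, is whether the loss follows from removing the 2,5-dimethoxyphenyl or from the entering ring itself, and a 2,5-dihydroxyphenyl group or a morpholine at this place would help to separate the two. Also open, on these data alone, is whether the chloro on the phenyl group would lower the number when the entering ring is present, and whether the free sulfonamide would behave like the acetylated one there.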